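The compounds below may be only part of what the source reports. "The series", "measured", "known", "first", "only" and "open" are said of these compounds alone.

Of the compounds shown here, two built on one shared core have been tested so far. In a functional assay on the whole organism (Tail, strain ICR) with Mus musculus as the target, in the tail flick test, with a stated time of 120 min, at a dose of 12.5 umol/kg by the oral route (a lower number here means a weaker effect, a higher number a stronger effect of the compound at the dose given), compound 1 `O=C(CN(c1nc(Cl)nc2[nH]cnc12)C1CC1)NCC(=O)OCc1ccccc1` gives 14.6%, which is the upper of the two numbers, yet compound 2 `N=C(N)NCCC[C@H](NC(=O)CN(c1nc(Cl)nc2[nH]cnc12)C1CC1)C(=O)O` gives 10.3% in this assay, a gap that lies within the usual scatter, so the two cannot be told apart. Compound 3 `CC(C)[C@H](NC(=O)CN(c1nc(Cl)nc2[nH]cnc12)C1CC1)C(=O)OCc1ccccc1` awaits measurement in this assay. It differs from compound 1 by isopropyl in place of hydrogen on a saturated chain carbon bound to an amide-type nitrogen and a carbonyl carbon. Among the measured compounds shown here, no measured pair shows what such a change does, so only a small step, a number 3.4 percentage points higher from compound 1 to compound 3 (within the scatter), is expected, not clearly beyond the scatter in either direction. Compound 3 is therefore estimated to give 18%, somewhere from 5% to 40%.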

Compound 3, a percentage reported as activity, at one dose (the size of the read-out at that dose, not a potency): 15%
Compound 3: the middle estimate sits 3 percentage points above what was measured; the range from low to high includes it.
By their numbers in this assay, from the lowest: compounds 2, 1 and 3 (each within the scatter of the next).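

Isopropyl in place of hydrogen on a saturated chain carbon bound to an amide-type nitrogen and a carbonyl carbon gives, in this assay, a number 0.4 percentage points higher from compound 1 to compound 3 (within the scatter), so this pair cannot be told apart. This first single-place comparison shows that adding isopropyl at this position leaves the read-out at this dose within the scatter. No measured evidence accounts for this result. On these data alone, whether an amine or a longer chain such as n-butyl on this same carbon would clearly separate from compound 1 remains open.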